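Fluoromethyl for methoxymethyl on the diaryl chain

The compounds below may be only part of what the source reports. "The series", "measured", "known", "first", "only" and "open" are said of these compounds alone.

Measured so far in a functional assay on HL-60 cells (Homo sapiens) for cytotoxicity, read by WST assay, with a stated time of 48 h; on this read-out lower numbers stand for stronger inhibition and higher numbers for weaker inhibition:
Compound 1, `COc1cc(C(c2ccc(O)c(OC)c2)[C@@H](C)[C@H](C)CO)ccc1O` — compound 1 gives > 100000 nM, which is a limit of the assay and not a number.
Compound 2, `CCCCC[C@H](C(C)C)C(c1ccc(O)c(OC)c1)c1ccc(O)c(OC)c1` — compound 2 gives 9600 nM.
Compound 3, `COC[C@@H](C)[C@H](C)C(c1ccc(O)c(OC)c1)c1ccc(O)c(OC)c1` — compound 3 gives 73000 nM.

Compound 3 stands at the highest of the two numbers that are numbers; the step of a 7.6-fold higher number from compound 2 to compound 3 (0.88 log units; beyond the scatter) separates it from compound 2. The one limit in the set is the limit of > 100000 nM in this assay, at which 1 of the 3 values shown sits.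

Compound 4 is `COc1cc(C(c2ccc(O)c(OC)c2)[C@@H](C)[C@H](C)CF)ccc1O`. Its difference from compound 3: fluoro in place of methoxy on a saturated chain carbon, four bonds along the chain from two aromatic carbons. Among the compounds with values here, two measured steps touch the chain at this end. The step of an at least 1.3-fold lower number from compound 1 to compound 3 (0.13 log units; that floor lies within the scatter) changes the same oxygen and stays within the scatter. The step of an at least 10-fold lower number from compound 1 to compound 2 (1.01 log units; beyond the scatter) exchanges the whole chain for 1-isopropylhexyl and is not the same kind of change. No measured step removes the oxygen of the methoxymethyl group, so nothing shown speaks for a step beyond the scatter in either direction.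

Compound 4 is therefore expected to sit close to compound 3, with the step of a 1.0-fold lower number from compound 3 to compound 4 (0.02 log units; within the scatter) estimated to lie within the scatter. The estimate for compound 4 is 70000 nM, between 25000 nM and 200000 nM.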

Compound 4, half-maximal inhibitory concentration: 32000 nM
The estimate for compound 4 lay 2.2-fold (0.34 log units) above the measured number; measured number inside the range.
By their numbers in this assay, from the lowest: compound 2; then compound 4; then compound 3. At a limit, above all of these: compound 1.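

In this assay, fluoro at this position, on a saturated chain carbon four bonds along the chain from two aromatic carbons, gives a 2.3-fold lower number from compound 3 to compound 4 (0.36 log units; beyond the scatter); the earlier change at the same oxygen, hydroxy to methoxy, showed only a floor within the scatter, so this is the first single change at this chain end that is shown to move the number. The short 2-(fluoromethyl)-1-methylpropyl chain still does not match 1-isopropylhexyl, with a 3.3-fold higher number from compound 2 to compound 4 (0.52 log units; beyond the scatter), so the change at the chain end closes only part of the distance to the long chain. Against hydroxy the change reads an at least 3.1-fold lower number from compound 1 to compound 4 (0.49 log units; beyond the scatter), which gives a floor and no exact size, since compound 1 stands at a limit: the limit of > 100000 nM in this assay, at which 1 of the 4 values shown sits.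

The compounds shown do not separate the loss of the methoxy oxygen from the arrival of fluorine, and a plain methyl or a chloromethyl end on the same chain would bear on that. Also open, as far as these compounds go, is whether fluoro keeps its step on a longer chain, and how an amine or a carboxylic acid at this end would read in this assay.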